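Does compound 4 lose strength without its free hydroxy?

The source may hold more compounds than are shown below. What is called first, only, known or untested is meant among the compounds shown, and "the series" means these compounds.

Measured in a functional assay on PC-3 cells (Homo sapiens) for inhibition; on this read-out higher numbers stand for weaker inhibition and lower numbers for stronger inhibition:
- Compound 1 `Cc1c(C(=O)N/N=C\c2cccc(F)c2)oc2cccc(O)c12`: >= 40000 nM (a limit of the assay, not a number)
- Compound 2 `Cc1c(C(=O)N/N=C\c2c(O)cccc2Cl)oc2cccc(O)c12`: 18700 nM
- Compound 3 `Cc1ccc(O)c(/C=N\NC(=O)c2oc3cccc(O)c3c2C)c1`: 7350 nM

Compound 3 has the lowest number of the three, making it the strongest inhibitor here. Compound 4 `COc1ccccc1/C=N\NC(=O)c1oc2cccc(O)c2c1C` carries 2-methoxyphenyl in place of 2-hydroxy-5-methylphenyl on a carbon with a double bond to nitrogen.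

Among the measured compounds shown here, two steps bear on this change, as each brings in a group with a hydroxy: an at least 5.4-fold lower number from compound 1 to compound 3 (0.73 log units; beyond the scatter) and an at least 2.1-fold lower number from compound 1 to compound 2 (0.33 log units; beyond the scatter). The group in compound 4 has no hydroxy, like the 3-fluorophenyl of compound 1, although a 2.5-fold lower number from compound 2 to compound 3 (0.41 log units; beyond the scatter) shows that hydroxy-bearing groups also differ. A weakening is therefore expected, estimated as a 2.7-fold higher number from compound 3 to compound 4 (0.43 log units; beyond the scatter).

For compound 4 the estimated value is 20000 nM, with an expected range of 9000 nM to 40000 nM.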

Compound 4, half-maximal inhibitory concentration: 32700 nM
Compound 4: the middle estimate sits 1.6-fold (0.21 log units) below what was measured; the range from low to high includes it.
By their numbers in this assay, from the lowest: compound 3; then compounds 2 and 4 (each within the scatter of the next). At a limit, above all of these: compound 1.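

Replacing 2-hydroxy-5-methylphenyl with 2-methoxyphenyl, which has no hydrogen-bond donor, gives a 4.4-fold higher number from compound 3 to compound 4 (0.65 log units; beyond the scatter). Against 2-chloro-6-hydroxyphenyl, the same group gives a 1.7-fold higher number from compound 2 to compound 4 (0.24 log units; within the scatter), and against 3-fluorophenyl it gives an at least 1.2-fold lower number from compound 1 to compound 4 (0.08 log units; that floor lies within the scatter), so only the group of compound 3 stands clearly apart from 2-methoxyphenyl. The value of compound 1 is a limit of the assay, not a number: the limit of >= 40000 nM in this assay, at which 1 of the 4 values shown sits.

The compounds shown do not separate the loss of the hydroxy from the loss of the methyl in this change. As far as these compounds go, how an amine or a carboxylic acid on this phenyl ring would fare also remains open.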